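Methoxy added to the phenyl of compound 1

The compounds below may be only part of what the source reports. "The series", "measured", "known", "first", "only" and "open" are said of these compounds alone.

Measured so far in (an ADME assay on microsomes from liver (Rattus norvegicus) for metabolic stability, read by LC-MS, in the presence of a further agent that is not named here; on this read-out higher numbers stand for fast clearance and lower numbers for slow clearance):
- compound 1 (`Cc1ncc(C)n2nc(-c3ccn4cc(-c5ccccc5)nc4n3)nc12`): (5.6 mL.min-1.g-1)
- compound 2 (`Cc1nc(-c2ccc3nc(-c4ccccc4)[nH]c3c2)nc2ccccc12`): (> 450 mL.min-1.g-1), a limit of the assay and not a number

For the measured compounds named here, compound 1 holds the only actual number (5.6 mL.min-1.g-1), which sits on the slow-clearance side of the scale. Compound 3 (`COc1ccccc1-c1cn2ccc(-c3nc4c(C)ncc(C)n4n3)nc2n1`) has methoxy in place of hydrogen on an aromatic carbon, ortho to a large group (methoxy in place of hydrogen on an aromatic carbon). Going by the values given here, no measured pair shows this change, so the expectation is tentative: a modest rise in (this assay). The expected step is (a 2.5-fold higher number from compound 1 to compound 3 (0.40 log units; beyond the scatter)). Compound 3 is estimated at (14 mL.min-1.g-1), with an expected range from (4 mL.min-1.g-1) to (50 mL.min-1.g-1).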

Compound 3, intrinsic clearance in microsomes: 9.1 mL.min-1.g-1
Beside the measured number, compound 3's estimate is 1.5-fold (0.19 log units) above it; low and high end bracket the measured number.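

In this assay, for the compounds shown here, the change from phenyl to 2-methoxyphenyl gives a 1.6-fold higher number from compound 1 to compound 3 (0.21 log units; within the scatter), the only measured pair. On this pair, methoxy ortho to a large group leaves the read-out indistinguishable from that of the unsubstituted phenyl. No measurement shown bears on why this is so.

On these data alone, whether a hydroxyl, an amine or a carboxylic acid at this place would behave the same remains open. So does the effect of methoxy on the other aromatic carbons of the phenyl.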